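Gem-dimethyl at the acid end of a thiophene hexanoic acid

The source may hold more compounds than are shown below. What is called first, only, known or untested is meant among the compounds shown, and "the series" means these compounds.

The measured compounds and their values in an assay on spleen (Cavia porcellus) with leukotriene B4 receptor 1 (Homo sapiens) as the target; on this read-out higher numbers stand for weaker inhibition and lower numbers for stronger inhibition:
compound 1 `O=C(O)CCCCCCc1ccsc1CCCc1ccc(Cl)cc1` gives 1000 nM
compound 2 `O=C(O)CCCCCCc1sccc1CCCc1ccccc1` gives 1000 nM
compound 3 `O=C(O)CCCCCCc1sc(-c2ccccc2)cc1CCCc1ccccc1` gives 1000 nM

Compound 3 stands level with compounds 1 and 2; the three values are within the scatter of one another, so no order among them can be read. Among the compounds with values here, the one step among measured compounds that differs in a single place, from compound 2 to compound 3, gave no change at the digits printed from compound 2 to compound 3 (within the scatter) on adding a phenyl in place of hydrogen on an aromatic carbon.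

Compound 4 `CC(C)(CCCCCc1sc(-c2ccccc2)cc1CCCc1ccccc1)C(=O)O` is not yet measured. It differs from compound 3 by 1-carboxy-1-methylethyl in place of carboxymethyl on a saturated chain carbon, five bonds along the chain from an aromatic carbon. Within the data shown here, none of the measured steps touches this part of the molecule: the only step on record concerns the aromatic ring, not the acid-bearing chain, so there is no direct precedent for the size or direction of this change. With the whole series sitting at one level in this assay, the plainest expectation is a step of no change at the digits printed from compound 3 to compound 4 (within the scatter) from compound 3 to compound 4, with a wide allowance either way. For compound 4 the estimate in this assay is therefore 1000 nM, with a range from 300 nM to 3000 nM.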

Compound 4, half-maximal inhibitory concentration: 800 nM
For compound 4 the middle estimate is 1.3-fold (0.10 log units) above the measured one; the range from low to high includes it.
By their numbers in this assay, from the lowest: compounds 4, 1, 2 and 3 (each within the scatter of the next).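

In this assay, 1-carboxy-1-methylethyl in place of carboxymethyl on a saturated chain carbon, five bonds along the chain from an aromatic carbon, gives a 1.3-fold lower number from compound 3 to compound 4 (0.10 log units; within the scatter). Within the data shown here, this is the first reading at the acid-bearing end of the chain, since the only earlier step concerned a phenyl on an aromatic carbon, and it shows that the larger group can stand at this place, with the carboxylic acid kept, while the number stays within the scatter of that of compound 3. No supporting measurement bears on this result.

The compounds shown leave open whether a tetrazole or an amide in place of the carboxylic acid, or a shorter or longer chain carrying it, would move the number in this assay beyond the scatter. They also leave open whether 1-carboxy-1-methylethyl would read the same on the core of compound 2, which lacks the added phenyl, so the two changes cannot yet be judged apart from each other.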